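Trimming the long chain of compound 1

This account rests on a few compounds, and the source may have more. Where it says the series, first, only, none or still open, it means among the compounds named here.

Of the compounds shown here, three built on a shared core have been tested in a functional assay on MCF7 cells (Homo sapiens) for antiproliferative activity, read by sulforhodamine B assay, with a stated time of 48 h (a lower number here means a stronger inhibitor, a higher number a weaker inhibitor), so far. Compound 1 (`CCCCCCCc1ccc(NS(=O)(=O)c2ccc(N3CCNC3=O)cc2)cc1`) gives only a limit (> 1000 nM) and no exact number. Compound 3 (`CC(C)(C)c1cc(NS(=O)(=O)c2ccc(N3CCNC3=O)cc2)cc(C(C)(C)C)c1`) also gives only a limit (> 1000 nM). Compound 1 therefore stands at the limit of > 1000 nM in this assay, at which 2 of the 3 values shown sit, and shares that position with compound 3. Within the data shown here, compound 2 (`Cc1ccc(C)c(NS(=O)(=O)c2ccc(N3CCNC3=O)cc2)c1`) is the only one with a true number (48 nM).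

Compound 4 (`CC(C)Cc1ccc(NS(=O)(=O)c2ccc(N3CCNC3=O)cc2)cc1`) has not yet been measured. Its structure differs from compound 1 in one place (isopropyl in place of hexyl on a saturated chain carbon bound to an aromatic carbon), with isopropyl in place of hexyl on a saturated chain carbon bound to an aromatic carbon.

Among the measured compounds shown here, no measured pair shows this change alone, so any forecast is loose. Compound 2 at 48 nM shows that the shared core can give strong inhibition, so a lower number is expected with the shorter chain. The expected step is an at least 4.0-fold lower number from compound 1 to compound 4 (0.60 log units; beyond the scatter) in the direction of stronger inhibition, beyond the usual scatter. For compound 4 the estimate is 250 nM with an expected range from 50 nM to 1000 nM in this measurement.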

Compound 4, half-maximal inhibitory concentration: > 1000 nM
Compound 4 gave a limit, no number (the forecaster's own chance of this, stated with the estimate: 20%); at least 4.0-fold (0.60 log units) between middle value and limit.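

In this assay compound 4 gives > 1000 nM, a limit and not a number. Compound 1 also gives a limit, so no step between compound 1 and compound 4 can be read: the limit of > 1000 nM in this assay, at which 3 of the 4 values shown sit.

The compounds shown leave open whether isopropyl in place of hexyl changes inhibition at all.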